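From 2-chlorophenyl to 3-chlorophenyl in the series

The source may report more compounds than this note shows. Statements on the series, on what has been measured and on what is new or still open speak of the compounds shown alone.

Going by the values given here, in a functional assay on K562 cells (Homo sapiens) for cytotoxicity, read by ELISA, with a stated time of 4 days (a higher number here means a weaker inhibitor, a lower number a stronger inhibitor), compound 1 `Cc1ccc(-c2cc(-c3ccoc3)cc(-c3ccc(Cl)s3)n2)cc1` gives 17900 nM and compound 2 `Clc1ccc(-c2cc(-c3ccoc3)cc(-c3ccccc3Cl)n2)s1` gives 15800 nM as the only other number so far. Among the compounds with values here, the single measured step is a 1.1-fold lower number from compound 1 to compound 2 (0.05 log units; within the scatter) and it places compound 2 level with compound 1, with no ranking possible between them.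

Compound 3 `Clc1cccc(-c2cc(-c3ccoc3)cc(-c3ccc(Cl)s3)n2)c1` keeps the shared core and differs from compound 2 by one change: 3-chlorophenyl in place of 2-chlorophenyl on an aromatic carbon with 3-chlorophenyl in place of 2-chlorophenyl on an aromatic carbon, next to the ring nitrogen. Within the data shown here, no measured pair yet shows this kind of swap, so the evidence is indirect. The group at this same place has been changed once, from 4-methylphenyl to 2-chlorophenyl, and that step of a 1.1-fold lower number from compound 1 to compound 2 (0.05 log units; within the scatter) stayed within the scatter. One step is thin support, so the range stays wide.

The expected change is a 1.1-fold lower number from compound 2 to compound 3 (0.02 log units; within the scatter) and nothing beyond the scatter is expected. Compound 3 is estimated at 15000 nM with an expected range of 7000 nM to 30000 nM in this assay.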

Compound 3, half-maximal inhibitory concentration: 22100 nM
For compound 3 the middle estimate is 1.5-fold (0.17 log units) below the measured one; the range from low to high includes it.
By their numbers in this assay, from the lowest: compounds 2, 1 and 3 (each within the scatter of the next).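

At this position, on an aromatic carbon next to the ring nitrogen, this assay still does not separate the three phenyl groups on the shared core: the numbers show a 1.4-fold higher number from compound 2 to compound 3 (0.15 log units; within the scatter) for 3-chlorophenyl in place of 2-chlorophenyl and a 1.2-fold higher number from compound 1 to compound 3 (0.09 log units; within the scatter) for 3-chlorophenyl in place of 4-methylphenyl. The earlier pair compared two different substituents, whereas this result adds a swap in which the same atoms are joined differently, and that swap also stays within the scatter. Among these compounds, therefore, the place of the chlorine on this phenyl group makes no readable difference, and no measurement at hand speaks to why the numbers lie so close together.

From the compounds shown here alone, whether a group of another kind at this place, such as a phenyl carrying an amine or a carboxylic acid, would give a number beyond the scatter remains open. All three compounds also share the 5-chlorothiophen-2-yl and furan-3-yl groups, so what those two places contribute to the numbers cannot be read from them.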